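Compound 3 gives up its hydroxy group

The source may hold more compounds than are shown below. What is called first, only, known or untested is meant among the compounds shown, and "the series" means these compounds.

Measured so far in a physicochemical assay for solubility; a lower number here means a less soluble compound, a higher number a more soluble compound:
- compound 1 `O=C(NC[C@H](NS(=O)(=O)c1cccs1)C(=O)O)c1ccc(N2CCC[C@H](NC3=NCCCN3)C2)cc1` (3300 ug/mL)
- compound 2 `O=C(NC[C@H](NS(=O)(=O)c1ccccc1)C(=O)O)c1ccc(N2CCC[C@H](NC3=NCCCN3)C2)cc1F` (2800 ug/mL)
- compound 3 `O=C(NC[C@H](NS(=O)(=O)c1ccc(O)cc1)C(=O)O)c1ccc(N2CCC(NC3=NCCCN3)CC2)c(F)c1` (100 ug/mL)

Compound 3 stands lowest of the three, beyond the usual scatter from both others. Compound 4 `O=C(NC[C@H](NS(=O)(=O)c1ccccc1)C(=O)O)c1ccc(N2CCC(NC3=NCCCN3)CC2)c(F)c1` differs from it in one place, with hydrogen in place of hydroxy on an aromatic carbon, para to a large group (hydrogen in place of hydroxy on an aromatic carbon). So 4-hydroxyphenyl becomes phenyl. For the measured compounds named here, no measured pair shows this change alone. Compound 2 (2800 ug/mL) also carries phenylsulfonyl, yet it differs from compound 4 elsewhere too, so it offers only a weak hint of a rise. A modest rise is expected (a 2.5-fold higher number from compound 3 to compound 4 (0.40 log units; beyond the scatter)), and a result within the scatter would be no surprise. For compound 4 the estimate is 250 ug/mL (expected range 70 ug/mL to 1500 ug/mL).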

Compound 4, solubility: 600 ug/mL
Compound 4: the middle estimate sits 2.4-fold (0.38 log units) below what was measured, and the stated range covers the measured number.
By their numbers in this assay, from the lowest: compound 3; then compound 4; then compounds 2 and 1 (each within the scatter of the next).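

In this assay, hydrogen in place of hydroxy on an aromatic carbon, para to a large group, gives a 6.0-fold higher number from compound 3 to compound 4 (0.78 log units; beyond the scatter) with the rest of the structure unchanged. For the compounds shown here, this is the first pair here that differs in one place only, so the shift can be tied to this single change at this position. No measurement shown gives a reason for the shift. Going by these compounds, whether a methoxy group or an amine at the same place would land nearer compound 3 or compound 4 remains open. Also open, on these data alone, is whether the same change would give a step of this size on the core of compound 2.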